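The source may hold more compounds than are shown below. What is called first, only, known or untested is meant among the compounds shown, and "the series" means these compounds.

Measured so far in a functional assay for agonist activity at G protein-coupled receptor 88 (Homo sapiens), read by HTRF and cAMP accumulation; on this read-out lower numbers stand for an effect already at smaller amounts and higher numbers for an effect only at larger amounts of compound:
Compound 1 `CC[C@H](C)[C@H](N)CN(C(=O)[C@@H]1C[C@H]1c1nccs1)c1ccc(-c2ccccc2)cc1` gives 210 nM.
Compound 2 `CCCc1ccc(-c2ccc(N(C[C@@H](N)[C@@H](C)CC)C(=O)[C@@H]3C[C@H]3c3ccccc3)cc2)cc1` gives 61 nM.

Compound 2 holds the lowest of the two numbers in this assay; its nearest neighbour, compound 1, shows a higher number, and the gap between the two lies beyond the usual scatter. Among the measured compounds shown here, no pair among the measured compounds differs in a single place, so no isolated step can be read from them.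

Compound 3 `CC[C@H](C)[C@H](N)CN(C(=O)[C@@H]1C[C@H]1c1ccccc1)c1ccc(-c2ccc(CN)cc2)cc1` is not yet measured. It differs from compound 2 as follows: amino in place of ethyl on a saturated chain carbon bound to an aromatic carbon. Nothing in the measured pair isolates this kind of change, so the expectation for compound 3 is uncertain. A moderate move toward a higher number in this assay, beyond the scatter but not large, is expected as a 2.5-fold higher number from compound 2 to compound 3 (0.39 log units; beyond the scatter). For compound 3 the estimated value in this assay is 150 nM, within a range from 40 nM to 600 nM.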

Compound 3, half-maximal effective concentration: > 30000 nM
Compound 3: only a limit was reported; the forecaster's own chance of this, stated with the estimate: 5%; middle value at least 200-fold (2.30 log units) away from the limit.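

In this assay, the change from 4-propylphenyl to 4-(aminomethyl)phenyl, amino in place of ethyl on a saturated chain carbon bound to an aromatic carbon, gives an at least 490-fold higher number from compound 2 to compound 3 (2.69 log units; beyond the scatter). Among the compounds shown here, for the first time, a single place can be read, and this place proves highly sensitive to the change. The entry for compound 3 is a limit of the assay, not a number: the limit of > 30000 nM in this assay, at which 1 of the 3 values shown sits.

Open, on these data alone, is whether the step follows from the entering primary amine or from the loss of the propyl chain; a hydroxymethyl, a methoxymethyl or a butyl chain at this place would help separate the two. Also open, as far as these compounds go, is whether a tertiary amine such as dimethylaminomethyl, or an amine set further out on a longer chain, would meet the same outcome.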